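Series notes: compound 4, methyl in place of chloro

The compounds below may be only part of what the source reports. "The series", "measured", "known", "first", "only" and "open" are said of these compounds alone.

Measured so far:
compound 1 `NC(=O)C1CCN1Cc1ccc(OCc2cccc(F)c2)cc1` gives 18000 nM
compound 2 `C[C@H](NCc1ccc(OCc2cccc(F)c2)cc1Cl)C(N)=O` gives 12000 nM
compound 3 `C#CCN(Cc1ccc(OCc2cccc(F)c2)cc1Cl)[C@@H](C)C(N)=O` gives 5600 nM

In an assay on Sf9 cells for inhibition of Amine oxidase [flavin-containing] A (Homo sapiens), with stated times of 15 min and 60 min (a lower number here means a stronger inhibitor, a higher number a weaker inhibitor), compound 3 stands lowest of the three numbers; compound 2 sits above it and compound 1 higher still, both gaps beyond the scatter. Among the compounds with values here, the only single-point step in the set is a 2.1-fold lower number from compound 2 to compound 3 (0.33 log units; beyond the scatter), and it concerns the amine nitrogen, not the aromatic ring.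

Compound 4 `C#CCN(Cc1ccc(OCc2cccc(F)c2)cc1C)[C@@H](C)C(N)=O` differs from compound 3 by methyl in place of chloro on an aromatic carbon. Compound 1 and compound 2 differ from each other at that same ring carbon, but also at the amine and in the ring attached to the nitrogen, so their two values cannot be read as a clean test of this exchange. Within the data shown here, no measured step therefore bears directly on it. With nothing in the series pointing either way, the step from compound 3 to compound 4 is expected to stay within the scatter, no change at the digits printed from compound 3 to compound 4 (within the scatter). Compound 4 is accordingly estimated at 5600 nM, with a range of 2500 nM to 12500 nM.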

Compound 4, half-maximal inhibitory concentration: 6400 nM
For compound 4 the middle estimate is 1.1-fold (0.06 log units) below the measured one; measured number inside the range.
By their numbers in this assay, from the lowest: compounds 3, 4, 2 and 1 (each within the scatter of the next, the first and the last beyond it).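

In this assay, within the data shown here, methyl in place of chloro on this aromatic carbon gives a 1.1-fold higher number from compound 3 to compound 4 (0.06 log units; within the scatter) and provides the first direct reading of this position. With the propargyl group on the amine nitrogen held constant, the two single-atom groups at this carbon, ortho to a large group, cannot be told apart in this assay. The data at hand offer no explanation for this equivalence. 

On these data alone, whether the exchange reads the same in the secondary amine of compound 2 remains open, as the methyl group appears here only beside the propargyl group. Also open, as far as these compounds go, is how this carbon would respond to a group such as methoxy, trifluoromethyl or a carboxylic acid, or to hydrogen in a pair differing only at this place.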